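The source may report more compounds than this note shows. Statements on the series, on what has been measured and on what is new or still open speak of the compounds shown alone.

Measured in a functional assay on cells for inhibition, with Murine T-cell line (Mus musculus) as the target; a lower number here means a stronger inhibitor, a higher number a weaker inhibitor:
compound 1, `CC[C@@H]1/C=C(\C)C[C@H](C)C[C@H](OC)[C@H]2O[C@@](O)(C(=O)C(=O)N3CCCC[C@H]3C(=O)O[C@H](/C(C)=C/[C@@H]3CC[C@@H](Oc4ccc(C(F)(F)F)cc4)[C@H](OC)C3)[C@H](C)[C@@H](O)CC1=O)[C@H](C)C[C@@H]2OC`: 35.8 nM
compound 2, `CC[C@@H]1/C=C(\C)C[C@H](C)C[C@H](OC)[C@H]2O[C@@](O)(C(=O)C(=O)N3CCCC[C@H]3C(=O)O[C@H](/C(C)=C/[C@@H]3CC[C@@H](Oc4ccc(C)cc4)[C@H](OC)C3)[C@H](C)[C@@H](O)CC1=O)[C@H](C)C[C@@H]2OC`: 2.7 nM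
compound 3, `CC[C@@H]1/C=C(\C)C[C@H](C)C[C@H](OC)[C@H]2O[C@@](O)(C(=O)C(=O)N3CCCC[C@H]3C(=O)O[C@H](/C(C)=C/[C@@H]3CC[C@@H](Oc4cccc(O)c4)[C@H](OC)C3)[C@H](C)[C@@H](O)CC1=O)[C@H](C)C[C@@H]2OC`: 1.7 nM

Compound 3 gives the lowest of the three numbers in this assay. Compound 2 stands nearest, separated by a 1.6-fold lower number from compound 2 to compound 3 (0.20 log units; within the scatter), so these two cannot be ranked against each other. Compound 1 stands furthest, separated by a 21-fold lower number from compound 1 to compound 3 (1.32 log units; beyond the scatter). Among the measured compounds shown here, the remaining comparison across the set, a 13-fold lower number from compound 1 to compound 2 (1.12 log units; beyond the scatter), is likewise large; both large steps run from compound 1, the only member with trifluoromethyl.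

Compound 4 is `CC[C@@H]1/C=C(\C)C[C@H](C)C[C@H](OC)[C@H]2O[C@@](O)(C(=O)C(=O)N3CCCC[C@H]3C(=O)O[C@H](/C(C)=C/[C@@H]3CC[C@@H](Oc4cccc(OC)c4)[C@H](OC)C3)[C@H](C)[C@@H](O)CC1=O)[C@H](C)C[C@@H]2OC`, not yet measured. It differs from compound 3 as follows: methyl in place of hydrogen on an oxygen on an aromatic ring

For the measured compounds named here, no measured step shows a methyl placed on an oxygen on an aromatic ring, so there is no direct precedent. The nearest comparison is the exchange of one aryl group on the ether oxygen for another, which stays within the scatter a 1.6-fold lower number from compound 2 to compound 3 (0.20 log units; within the scatter). The large steps concern removal of trifluoromethyl and do not bear on this change. On that basis, the step from compound 3 to compound 4 in this assay is expected to be small, a 1.5-fold higher number from compound 3 to compound 4 (0.17 log units; within the scatter), with no change beyond the scatter. Compound 4 is estimated at 2.5 nM, within the range 1 nM to 6.5 nM.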

Compound 4, half-maximal inhibitory concentration: 3.4 nM
For compound 4 the middle estimate is 1.4-fold (0.13 log units) below the measured one; measured number inside the range.
By their numbers in this assay, from the lowest: compounds 3, 2 and 4 (each within the scatter of the next); then compound 1.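

Methoxy in place of hydroxy at this position leaves the number in this assay essentially unchanged, with a 2.0-fold higher number from compound 3 to compound 4 (0.30 log units; within the scatter) the whole of the step, so on this evidence the free hydroxy hydrogen of compound 3 is not required for a low nanomolar number. The 3-methoxyphenyl ether also cannot be separated from the 4-methylphenyl ether, given a 1.3-fold higher number from compound 2 to compound 4 (0.10 log units; within the scatter), and the large gap to the trifluoromethyl member persists, with an 11-fold lower number from compound 1 to compound 4 (1.02 log units; beyond the scatter), leaving compound 1 as the only one of the four standing apart. Nothing on hand accounts for any of these steps.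

Open, as far as these compounds go, is how far this position accepts change on the oxygen, since a longer chain such as ethoxy or propoxy, or an amine or a carboxylic acid in place of the hydroxy, would test more than the single added methyl seen here. Also open is whether trifluoromethyl carries the same penalty on the 3-position of the phenyl ring, as the compounds shown carry that group only in 4-(trifluoromethyl)phenyl.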